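From methyl to ethyl on an aromatic nitrogen

This account rests on a few compounds, and the source may have more. Where it says the series, first, only, none or still open, it means among the compounds named here.

- compound 1 `COc1ccc(-c2cc3c(cn2)[nH]c(=O)n3-c2cc(OC)c(OC)c(OC)c2)cc1O` gives 490 nM
- compound 2 `COc1ccc(-c2cc3c(cn2)n(C)c(=O)n3-c2cc(OC)c(OC)c(OC)c2)cc1O` gives 2220 nM

Both numbers come from a functional assay on HeLa cells (Homo sapiens) for antiproliferative activity, read by MTT assay, with a stated time of 48 h (a higher number here means a weaker inhibitor, a lower number a stronger inhibitor), and compound 2 stands highest of the two, making it the weaker inhibitor. Compound 3 `CCn1c(=O)n(-c2cc(OC)c(OC)c(OC)c2)c2cc(-c3ccc(OC)c(O)c3)ncc21` differs from compound 2 by methyl in place of hydrogen on a saturated chain carbon bound to an aromatic nitrogen in one place, which reads methyl to ethyl. Among the measured compounds shown here, the one measured step that bears on this is a 4.5-fold higher number from compound 1 to compound 2 (0.66 log units; beyond the scatter) for methyl in place of hydrogen on an aromatic nitrogen. One step sets no rule, but a further modest rise in this assay is expected. The estimated move is a 1.4-fold higher number from compound 2 to compound 3 (0.13 log units; within the scatter) for this change. Compound 3 is estimated at 3000 nM and between 1200 nM and 7500 nM is where it is expected to fall.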

Compound 3, half-maximal inhibitory concentration: > 20000 nM
Compound 3 gave a limit, no number (the forecaster's own chance of this, stated with the estimate: 5%); middle value at least 6.6-fold (0.82 log units) from the limit.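

Adding to the methyl on this aromatic nitrogen weakens the compound further, with ethyl giving an at least 9.0-fold higher number from compound 2 to compound 3 (0.95 log units; beyond the scatter). Set against the unsubstituted nitrogen, ethyl gives an at least 40-fold higher number from compound 1 to compound 3 (1.61 log units; beyond the scatter), so in this assay the numbers rise with each step across these three compounds. Compound 3 is recorded only as a limit, not a number: the limit of > 20000 nM in this assay, at which 1 of the 3 values shown sits.

The compounds shown leave open whether a longer chain, or a chain ending in an amine, would fare like ethyl. On these data alone, the true size of the ethyl step also stays unknown.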